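This account rests on a few compounds, and the source may have more. Where it says the series, first, only, none or still open, it means among the compounds named here.

Working notes on the series. The shared core is carried by compound 1 `COc1ccc(-c2cnc(NC(=O)CCCCCCNC(=O)C(O)(O)C(F)(F)F)s2)cc1` and compound 2 `COc1ccc(NC(=O)CCCCCCNC(=O)C(O)(O)C(F)(F)F)cc1`, which differ in the aryl piece attached to the amide. In a functional assay on HCT-116 cells (Homo sapiens) for inhibition, read by colorimetric assay, with a stated time of 3 days (on this read-out higher numbers stand for weaker inhibition and lower numbers for stronger inhibition), compound 1 gives 930 nM. In this assay compound 2 gives 4520 nM, the highest of the two numbers shown; the gap to compound 1 lies beyond the scatter. Compound 3 `O=C(CCCCCNC(=O)c1ccc[nH]1)Nc1ccccc1` belongs to a different amide series; in this assay compound 3 gives > 100000 nM, which is a limit of the assay rather than a number, as the limit of > 100000 nM in this assay, at which 1 of the 3 values shown sits, shows.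

Compound 4 `O=C(CCCCCCNC(=O)C(O)(O)C(F)(F)F)Nc1ccc(Cl)cc1` has not yet been measured in this assay. It differs from compound 2 by chloro in place of methoxy on an aromatic carbon. Within the data shown here, no step between measured compounds touches this position, so there is nothing in the data to fix the size or direction of the change. The step from compound 2 to compound 4 is expected to fall within the scatter, a 1.3-fold lower number from compound 2 to compound 4 (0.11 log units; within the scatter). For compound 4 in this assay the estimate is 3500 nM, with a range from 1000 nM to 15000 nM.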

Compound 4, half-maximal inhibitory concentration: 4230 nM
Compound 4: middle estimate off by 1.2-fold (0.08 log units), on the low side, within the range that was stated.
By their numbers in this assay, from the lowest: compound 1; then compounds 4 and 2 (each within the scatter of the next). At a limit, above all of these: compound 3.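

Among these compounds, no step among the earlier compounds touched this position, so this is the only reading of it so far: on an aromatic carbon para to a large group, this assay gives a 1.1-fold lower number from compound 2 to compound 4 (0.03 log units; within the scatter) for chloro in place of methoxy. At this position the two groups therefore cannot be told apart in this read-out, even though the change removes a heavy atom and a hydrogen-bond acceptor. Nothing in the available evidence bears on this result.

Open, as far as these compounds go, is whether an amine or a carboxylic acid at this position would read the same as methoxy and chloro. Also open, from the compounds shown here alone, is whether chloro in place of methoxy stays as silent on the 4-methoxyphenyl group of compound 1, where the aryl piece attached to the amide differs.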